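This account rests on a few compounds, and the source may have more. Where it says the series, first, only, none or still open, it means among the compounds named here.

In a functional assay on L5178Y cells (Mus musculus) for cytotoxicity, read by MTT assay (a higher number here means that more compound is needed for the effect, a lower number that less compound is needed), compound 1 `CC(=O)[C@]1(CC/C(C)=C/CC/C(C)=C/CCC2=CC(=O)OC2O)[C@@H](O)CCC1(C)C` gives only the limit > 10 ug/mL, not a number. Compound 2 `CC(=O)[C@]1(CC/C(C)=C/CC/C(C)=C/CCC2=CC(=O)OC2O)[C@H](O)CCC1(C)C`, which differs from it only in how one stereocentre at a saturated ring carbon is drawn, gives 7 ug/mL; the step of an at least 1.4-fold lower number from compound 1 to compound 2 (0.15 log units; that floor lies within the scatter) rests on the limit of > 10 ug/mL in this assay, at which 1 of the 3 values shown sits, and on (the fact that one of compounds 1 and 2 is drawn with a defined configuration and the other without, at the place where they differ). Compound 3 `CC1=C(CC/C(C)=C/CC/C(C)=C/CCC2=CC(=O)OC2O)C(C)(C)CCC1` gives 3.3 ug/mL, the lower of the two numbers measured here, with compound 2 the nearest to it. Compound 4 `COC1OC(=O)C=C1CC/C=C(\C)CC/C=C(\C)CCC1=C(C)CCCC1(C)C` differs from compound 3 by methyl in place of hydrogen on an oxygen on a saturated carbon. Going by the values given here, no measured step involves a change of this kind; the only measured step, from compound 1 to compound 2, concerns stereochemistry alone. The step of no change at the digits printed from compound 3 to compound 4 (within the scatter) is therefore expected to be none beyond the scatter. Compound 4 is expected to give about 3.3 ug/mL, between 1.5 ug/mL and 8 ug/mL.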

Compound 4, concentration for half-maximal effect: 0.7 ug/mL
Compound 4: the middle estimate sits 4.7-fold (0.67 log units) above what was measured; the measured number lies below the stated range.
By their numbers in this assay, from the lowest: compound 4; then compound 3; then compound 2. At a limit, above all of these: compound 1.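

In this assay the change from hydroxy to methoxy gives a 4.7-fold lower number from compound 3 to compound 4 (0.67 log units; beyond the scatter), so what this oxygen carries matters in this assay. The earlier compounds shown here all kept the hydroxy here, so they could not show this. Nothing given here explains the size of the step. Going by these compounds, whether an ethyl on this oxygen, or an amine in place of the hydroxy, would lower the number further remains open. So does whether the same methyl would have a similar effect in compound 2.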